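The compounds below may be only part of what the source reports. "The series", "measured", "known", "first", "only" and "open" are said of these compounds alone.

Of the compounds shown here, three have so far been tested in an ADME assay on HEL cells (Homo sapiens) for cytotoxicity, with a stated time of 3 days; a higher number here means that more compound is tolerated, a lower number that less compound is tolerated. Compound 1 `Cc1cc(-c2ccccc2)c2ncc(CSCCc3ccccc3)n2c1` gives 20 ug/mL, and compound 2 `c1ccc(CCSCc2cnc3ccc(-c4ccccc4)cn23)cc1` gives 4 ug/mL. For compound 3 `Cc1cc(-c2ccsc2)cn2c(CSCCc3ccccc3)cnc12` the assay reports only a limit, >= 4 ug/mL, not a number. That is where compound 3 stands: at the limit of >= 4 ug/mL in this assay, at which 1 of the 3 values shown sits, with nothing more precise known for it. Compound 4 `Cc1cc(-c2ccccc2O)cn2c(CSCCc3ccccc3)cnc12` has not yet been measured. It differs from compound 3 in one place: 2-hydroxyphenyl in place of thiophen-3-yl on an aromatic carbon. Among the measured compounds shown here, no measured pair of compounds shows this change, so there is no step to lean on; the expected step that the limit leaves unreadable from compound 3 to compound 4 is small, not beyond the usual scatter. Compound 4 is therefore estimated at 8 ug/mL, with a likely range from 4 ug/mL to 40 ug/mL.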

Compound 4, minimum cytotoxic concentration: 100 ug/mL
For compound 4 the middle estimate is 13-fold (1.10 log units) below the measured one; measured number outside the range, above it.
By their numbers in this assay, from the lowest: compound 2; then compound 1; then compound 4.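

Among the compounds shown here, the value for compound 3 is a limit and not a number, so no step from compound 3 to compound 4 can be read: the limit of >= 4 ug/mL in this assay, at which 1 of the 4 values shown sits. The compounds shown leave open whether 2-hydroxyphenyl in place of thiophen-3-yl changes the tolerated concentration at all, and by how much.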